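Ether Linker in Place of Methylamino on the Pyridine Side

The source may report more compounds than this note shows. Statements on the series, on what has been measured and on what is new or still open speak of the compounds shown alone.

Compound 3 `CN(Cc1cccc(C(=O)O)c1)c1ccc(OCc2c(-c3c(Cl)cccc3Cl)noc2C2CC2)nc1C(F)(F)F` gives the lowest number of the three measured compounds in a functional assay on HEK293 cells for agonist activity at Bile acid receptor (Homo sapiens); on this read-out lower numbers stand for an effect already at smaller amounts and higher numbers for an effect only at larger amounts of compound: compound 3 gives 9 nM, while compound 2 `CC(C)c1onc(-c2c(Cl)cccc2Cl)c1COc1ccc(N(C)Cc2cccc(C(=O)O)c2)c(C(F)(F)F)n1` gives 80 nM and compound 1 `CC(C)c1onc(-c2c(Cl)cccc2Cl)c1COc1ccc(N(C)C(=O)c2cccc(C(=O)O)c2)c(C(F)(F)F)n1` gives 571 nM. The steps behind this ranking were a 7.1-fold lower number from compound 1 to compound 2 (0.85 log units; beyond the scatter) and an 8.9-fold lower number from compound 2 to compound 3 (0.95 log units; beyond the scatter), both beyond the scatter.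

Compound 4 `CC(Oc1cccc(C(=O)O)c1)c1ccc(OCc2c(-c3c(Cl)cccc3Cl)noc2C2CC2)nc1C(F)(F)F` carries 1-(3-carboxyphenoxy)ethyl in place of (3-carboxybenzyl)(methyl)amino on an aromatic carbon. Neither measured step touches this part of the molecule in the same way: the step from compound 1 to compound 2 altered the link between the aromatic nitrogen and the carboxyphenyl group, and the step from compound 2 to compound 3 altered a group on the other side of the shared core. Among the measured compounds shown here, the only guidance is that a change of the linker, as from compound 1 to compound 2, can move this assay by a modest amount.

Compound 4 is therefore expected to show a 2.8-fold higher number from compound 3 to compound 4 (0.44 log units; beyond the scatter) in this assay, a modest rise in the number, with wide uncertainty. Compound 4 is estimated at 25 nM, with a range from 6 nM to 120 nM.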

Compound 4, half-maximal effective concentration: 107 nM
Compound 4: middle estimate off by 4.3-fold (0.63 log units), on the low side; measured number inside the range.
By their numbers in this assay, from the lowest: compound 3; then compounds 2 and 4 (each within the scatter of the next); then compound 1.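

In this assay, placing 1-(3-carboxyphenoxy)ethyl in place of (3-carboxybenzyl)(methyl)amino on this aromatic carbon, ortho to a trifluoromethyl group, gives a 12-fold higher number from compound 3 to compound 4 (1.08 log units; beyond the scatter) as a large step. The two groups have the same number of heavy atoms, the same carbon-only aromatic ring and the same counts of hydrogen-bond donors and acceptors, so matching these counts does not keep the number low at this position. No measurement at hand accounts for the rise.

The compounds shown leave open which part of the exchange carries the step, since the nitrogen and its methyl group are replaced together with the rest of the link. A 3-carboxyphenoxymethyl group, or an amine link bearing the same branching methyl, would help to separate these parts.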